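This account rests on a few compounds, and the source may have more. Where it says the series, first, only, none or still open, it means among the compounds named here.

Compound 1 `COc1c(OC)c(OC(=O)C(C)(C)C)c2ccccc2c1OC(=O)C(C)(C)C` gives 5.69 in a physicochemical assay for lipophilicity; on this read-out lower numbers stand for lower lipophilicity and higher numbers for higher lipophilicity.
Compound 2 `O=C(Oc1c(Oc2ccccc2)c(Oc2ccccc2)c(OC(=O)c2ccccc2)c2ccccc12)c1ccccc1` gives 7.9 in this assay.
Compound 3 `COc1c(OC)c(OC(=O)C(C)(C)C)c2c(Cl)cccc2c1OC(=O)C(C)(C)C` gives 6.1 in this assay.

Compound 3 differs from compound 1 by chloro in place of hydrogen on an aromatic carbon, and this gave a number 0.41 log units higher from compound 1 to compound 3 (beyond the scatter). Compound 2 stands highest of the three; how its core differs from that of compound 1 is not broken down here. Compound 4 `O=C(Oc1c(Oc2ccccc2)c(Oc2ccccc2)c(OC(=O)c2ccccc2)c2cc(Cl)ccc12)c1ccccc1` differs from compound 2 by chloro in place of hydrogen on an aromatic carbon. This is the same kind of change as from compound 1 to compound 3, though the place differs: in compound 3 the chloro sits ortho to a fused ring and meta to a fused ring, in compound 4 meta to a fused ring and para to a fused ring. The expected step is a number 0.45 log units higher from compound 2 to compound 4 (beyond the scatter). This rests on the earlier step, a number 0.41 log units higher from compound 1 to compound 3 (beyond the scatter), made by the same kind of change. Compound 4 is expected to give 8.35, between 7.9 and 8.8.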

Compound 4, partition coefficient: 8.7
Beside the measured number, compound 4's estimate is 0.35 log units below it; measured number inside the range.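

In this assay, chloro in place of hydrogen on an aromatic carbon gives a number 0.80 log units higher from compound 2 to compound 4 (beyond the scatter), the same direction as a number 0.41 log units higher from compound 1 to compound 3 (beyond the scatter). The direction of the change therefore carried over from one core to the other in these two pairs, but the chloro also sits in a different place in each pair, so they cannot show whether the core or the place sets the size of a step. Nothing measured here explains the size of either step.

The compounds shown leave open whether an amine or a carboxylic acid in place of that hydrogen would move the number the same way. Going by these compounds, whether chloro would give the same direction on other cores also remains open.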